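This account rests on a few compounds, and the source may have more. Where it says the series, first, only, none or still open, it means among the compounds named here.

Compound 1 `Cc1noc(-c2nc(C)c3c(c2N)C(=O)N(Cc2ccc(Oc4ccc(F)cc4)cc2)C3=O)n1` gives 23800 nM in a physicochemical assay for solubility, using the shake flask method, in simulated intestinal fluid, measured as kinetic solubility, with a stated time of 2 h, at 25 degrees C, at pH 6.5; on this read-out higher numbers stand for higher solubility and lower numbers for lower solubility.
Compound 2 `Cc1noc(-c2nc(C)c3c(c2N)C(=O)N(Cc2ccc(-n4cccn4)cc2)C3=O)n1` gives < 5000 nM in this assay, a limit of the assay rather than a number.
Compound 3 `Cc1noc(-c2nc(C)c3c(c2N)C(=O)N(Cc2ccc(Br)cc2)C3=O)n1` gives < 5000 nM in this assay, likewise a limit of the assay.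

Within the data shown here, compound 1 thus holds the only number among the three; the other two values sit at the limit of < 5000 nM in this assay, at which 2 of the 3 values shown sit. Compound 4 `Cc1noc(-c2nc(C)c3c(c2N)C(=O)N(Cc2ccc(N(C)C)cc2)C3=O)n1` has not yet been measured in this assay. Against compound 1 it differs in one place: dimethylamino in place of 4-fluorophenoxy on an aromatic carbon. Among the measured compounds shown here, two measured steps bear on this change, each one also removing the 4-fluorophenoxy group from the same aromatic carbon: an at least 4.7-fold lower number from compound 1 to compound 2 (0.67 log units; beyond the scatter) and an at least 4.7-fold lower number from compound 1 to compound 3 (0.67 log units; beyond the scatter). The change to compound 4 is of the same kind, a smaller group in place of the 4-fluorophenoxy. A step down is therefore expected for compound 4 as well, roughly a 4.0-fold lower number from compound 1 to compound 4 (0.60 log units; beyond the scatter). Compound 4 is accordingly estimated at 6000 nM, with a range from 2500 nM to 15000 nM, and with a fair chance that the assay reports only a limit.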

Compound 4, solubility: 7400 nM
Compound 4: the middle estimate sits 1.2-fold (0.09 log units) below what was measured, and the stated range covers the measured number.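

Among these compounds, with dimethylamino on this aromatic carbon, para to a large group, a replacement for 4-fluorophenoxy gives a readable number in this assay for the first time, so the size of this change can be stated rather than bounded: a 3.2-fold lower number from compound 1 to compound 4 (0.51 log units; beyond the scatter). Against the other two replacements only floors can be read, an at least 1.4-fold higher number from compound 3 to compound 4 (0.17 log units; that floor lies within the scatter) and an at least 1.4-fold higher number from compound 2 to compound 4 (0.17 log units; that floor lies within the scatter), so these steps do not separate compound 4 from compound 3 or compound 2. Compound 2 and compound 3 remain at a limit of the assay: the limit of < 5000 nM in this assay, at which 2 of the 4 values shown sit.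

Going by these compounds, how far compound 2 and compound 3 truly lie from compound 4 stays open. Also open, on these data alone, is whether a morpholine, a carboxylic acid or a longer alkoxy chain at this place would hold the number of compound 1 or fall as compound 4 does.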